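The compounds below may be only part of what the source reports. "The series", "measured", "known", "first", "only" and "open" are said of these compounds alone.

Working notes on the series. Compound 3 `COc1ccccc1C(=O)Nc1cccc(NC(=O)C2CCC2)c1` stands at an assay limit in an in vitro functional assay on HEK293-A cells for antagonist activity at metabotropic glutamate receptor 5 (Rattus norvegicus), read by calcium flux (a higher number here means a weaker inhibitor, a lower number a stronger inhibitor), giving > 30000 nM. Compound 1 `COc1ccccc1C(=O)Nc1cccc(NC(=O)c2ccc(F)cc2)c1` likewise reports only a limit, > 30000 nM. Among the measured compounds shown here, compound 2 `COc1ccccc1C(=O)Nc1cccc(NC(=O)c2cccc(C#N)c2)c1` gives 1800 nM in this assay and is the only compound with a numeric value, the other two sitting at the limit of > 30000 nM in this assay, at which 2 of the 3 values shown sit. Measured steps at this carbonyl carbon are an at least 16-fold lower number from compound 1 to compound 2 (1.22 log units; beyond the scatter) and an at least 16-fold higher number from compound 2 to compound 3 (1.22 log units; beyond the scatter), both large, while a step that the two limits leave unreadable from compound 1 to compound 3 cannot be read. Compound 4 `COCC(=O)Nc1cccc(NC(=O)c2ccccc2OC)c1` arises by methoxymethyl in place of cyclobutyl on a carbonyl carbon. No measured step exchanges one non-aromatic group for another here, so nothing shown points to a move off the limit. Compound 4 is expected to give 30000 nM, with a range of 8000 nM to 100000 nM. The expected step is thus a number no higher from compound 3 to compound 4 (the limit leaves the size open).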

Compound 4, half-maximal inhibitory concentration: > 30000 nM
Compound 4 was reported as a limit (the forecaster's own chance of this, stated with the estimate: 70%); the middle value lies on the limit itself.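

With methoxymethyl on this carbonyl carbon, compound 4 is a second non-aromatic group, after the cyclobutyl of compound 3, to report only a limit in this assay, so an open chain carrying an oxygen does no better here than the carbon-only ring: the limit of > 30000 nM in this assay, at which 3 of the 4 values shown sit.

Methoxymethyl in place of 3-cyanophenyl gives an at least 16-fold higher number from compound 2 to compound 4 (1.22 log units; beyond the scatter). The steps among compound 1, compound 3 and compound 4 cannot be read.

From the compounds shown here alone, whether any non-aromatic group at this place can give a numeric value stays open. An aminomethyl group or a carboxylic acid on this carbonyl carbon would test that.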